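A few compounds are considered here, and "the series" means these few. Any claim that something is new, unique, unknown or untested is made for them only; others in the source may bear on it.

Compound 3 `ClCc1ccc(Cn2cnc3c(Cl)nc(Cl)nc32)cc1` and compound 1 `Nc1nc(Cl)c2ncn(Cc3ccc(CCl)cc3)c2n1` share one core and differ in a single place, (amino in place of chloro on an aromatic carbon). In a functional assay on A549 cells (Homo sapiens) for cytotoxicity, read by sulforhodamine B assay, with a stated time of 48 h (on this read-out higher numbers stand for weaker inhibition of growth and lower numbers for stronger inhibition of growth), compound 3 gives 37200 nM, while compound 1 gives 75900 nM, so that a 2.0-fold higher number from compound 3 to compound 1 (0.31 log units; beyond the scatter). Compound 2 `ClCc1cccc(Cn2cnc3c(Cl)nc(Cl)nc32)c1` gives 10000 nM in this assay, the lowest of the three numbers; how its core differs from that of compound 3 is not broken down here. Compound 4 `Nc1nc(Cl)c2ncn(Cc3cccc(CCl)c3)c2n1` has not yet been measured and differs from compound 2 by the same change, (amino in place of chloro on an aromatic carbon), at the same place. Because that change gave a 2.0-fold higher number from compound 3 to compound 1 (0.31 log units; beyond the scatter), a step of about that size is expected again, a 2.0-fold higher number from compound 2 to compound 4 (0.30 log units; within the scatter). Compound 4 is therefore estimated at 20000 nM in this assay, most likely between 8000 nM and 50000 nM.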

Compound 4, concentration for total growth inhibition: 27500 nM
Estimate against measurement, compound 4: 1.4-fold (0.14 log units) below, within the range that was stated.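

On the second core, amino in place of chloro on an aromatic carbon gives a 2.8-fold higher number from compound 2 to compound 4 (0.44 log units; beyond the scatter) in this assay. The change therefore carries across these two cores in the same direction, and the two steps do not differ in size: the same change on two cores in this assay, a 2.0-fold higher number (0.31 log units; beyond the scatter) from compound 3 to compound 1 and a 2.8-fold higher number (0.44 log units; beyond the scatter) from compound 2 to compound 4, 1.3-fold (0.13 log units) apart, within the scatter of two such steps. This rests on two pairs only, so it does not show that the step would hold on any other core, and it does not explain why the numbers rise.

The compounds shown leave open what a methylamino or methoxy group would do at that same place. They also leave open how the numbers would respond if a hydroxymethyl group stood in place of the chloromethyl group.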